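A few compounds are considered here, and "the series" means these few. Any claim that something is new, unique, unknown or untested is made for them only; others in the source may bear on it.

Working notes on the series. All members share one core and differ only in the aryl group on the triazole nitrogen. Compound 1 `C/C(=C\CC/C(C)=C/CC[C@@H]1[C@@]2(C)CCC(=O)C(C)(C)[C@H]2CC[C@@]1(C)O)CC/C=C(\C)C(=O)OCc1cn(-c2ccccc2Cl)nn1` carries a 2-chlorophenyl. In a functional assay on MDA-MB-231 cells (Homo sapiens) for antiproliferative activity, read by MTT assay, with a stated time of 48 h (a lower number here means a stronger inhibitor, a higher number a weaker inhibitor), compound 1 gives > 150000 nM, which is a limit of the assay, not a number. Compound 2 `C/C(=C\CC/C(C)=C/CC[C@@H]1[C@@]2(C)CCC(=O)C(C)(C)[C@H]2CC[C@@]1(C)O)CC/C=C(\C)C(=O)OCc1cn(-c2ccccc2C)nn1` carries a 2-methylphenyl. In this assay compound 2 gives > 150000 nM, again a limit. Compound 3 `C/C(=C\CC/C(C)=C/CC[C@@H]1[C@@]2(C)CCC(=O)C(C)(C)[C@H]2CC[C@@]1(C)O)CC/C=C(\C)C(=O)OCc1cn(-c2cccc(C(F)(F)F)c2)nn1` carries a 3-(trifluoromethyl)phenyl. In this assay compound 3 gives > 150000 nM, also a limit. For the measured compounds named here, the steps a step that the two limits leave unreadable from compound 1 to compound 2, a step that the two limits leave unreadable from compound 1 to compound 3 and a step that the two limits leave unreadable from compound 2 to compound 3 therefore cannot be sized, since every value so far sits at the limit of > 150000 nM in this assay, at which 3 of the 3 values shown sit. Compound 2 thus stands only at a limit, level with the other two members on the numbers shown.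

Compound 4 `C/C(=C\CC/C(C)=C/CC[C@@H]1[C@@]2(C)CCC(=O)C(C)(C)[C@H]2CC[C@@]1(C)O)CC/C=C(\C)C(=O)OCc1cn(-c2ccccc2Br)nn1` differs from compound 2 by bromo in place of methyl on an aromatic carbon. Going by the values given here, no measured step involves bromo, and the steps measured so far at the aryl group were all unreadable between limits, so no readable step is expected in this assay: the step that the limit leaves unreadable from compound 2 to compound 4 is the expectation. Compound 4 is estimated at 200000 nM, in the range 100000 nM to 500000 nM, most probably reported again only as a limit.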

Compound 4, half-maximal inhibitory concentration: > 150000 nM
Compound 4 ended at the assay's limit; the forecaster's own chance of this, stated with the estimate: 85%; the middle value lies beyond the limit too.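

The steps linking compound 4 with compound 1, compound 2 and compound 3 cannot be read, since all four values are limits and not numbers: the limit of > 150000 nM in this assay, at which 4 of the 4 values shown sit. The compounds shown leave open whether any aryl group on the triazole nitrogen gives a measurable value in this assay.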